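This account rests on a few compounds, and the source may have more. Where it says the series, first, only, none or still open, it means among the compounds named here.

Compound 1 `CNCC(=O)Nc1cc(OC)ccc1C(=O)c1ccc2c(c1)C=CC(C)(C)O2` and compound 2 `CCNCC(=O)Nc1cc(OC)ccc1C(=O)c1ccc2c(c1)C=CC(C)(C)O2` share one core and differ in a single place: methyl in place of hydrogen on a saturated chain carbon bound to an amine nitrogen. In a functional assay on MCF7 cells (Homo sapiens) for antiproliferative activity, read by MTT assay, with a stated time of 48 h (a higher number here means a weaker inhibitor, a lower number a stronger inhibitor), compound 1 gives 1210 nM, whereas compound 2 gives 6310 nM, so this change produced the step of a 5.2-fold higher number from compound 1 to compound 2 (0.72 log units; beyond the scatter). Compound 3 `C=C(c1ccc(OC)cc1NC(=O)CNC)c1ccc(OC)c2c1OC(C)(C)C=C2` is built on a different core; the difference between the two cores is not broken down here. In this assay compound 3 gives 400 nM, the lowest of the three numbers. Compound 4 `C=C(c1ccc(OC)cc1NC(=O)CNCC)c1ccc(OC)c2c1OC(C)(C)C=C2` carries the same change on that second core: methyl in place of hydrogen on a saturated chain carbon bound to an amine nitrogen. Because the same change once gave a 5.2-fold higher number from compound 1 to compound 2 (0.72 log units; beyond the scatter), a step of similar size is expected here, a 4.5-fold higher number from compound 3 to compound 4 (0.65 log units; beyond the scatter), though a single earlier example is thin ground for that expectation. For compound 4 in this assay the expected value is therefore 1800 nM, plausibly lying between 700 nM and 5000 nM.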

Compound 4, half-maximal inhibitory concentration: 2100 nM
Compound 4: middle estimate off by 1.2-fold (0.07 log units), on the low side; measured number inside the range.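

On the second core, going from methylamino to ethylamino gives a 5.3-fold higher number from compound 3 to compound 4 (0.72 log units; beyond the scatter) in this assay. The change therefore shifts the number by about the same amount on both cores, and the two steps cannot be told apart: the same change on two cores in this assay, a 5.2-fold higher number (0.72 log units; beyond the scatter) from compound 1 to compound 2 and a 5.3-fold higher number (0.72 log units; beyond the scatter) from compound 3 to compound 4, 1.0-fold (0.00 log units) apart, within the scatter of two such steps. This shows that, for these two pairs, the size of the step carried over from one core to the other, but two pairs do not make a rule for other cores, and they do not explain why the number rises.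

The compounds shown leave open what a longer chain, such as propyl, would do on this amine nitrogen. They also leave open how a primary amine would compare on either core.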